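The compounds below may be only part of what the source reports. "The series", "measured", "known", "first", "only" and "open" are said of these compounds alone.

Measured compounds:
compound 1 `C[C@H](O)[C@@H](CCC1CCCCC1)n1cnc2c(N)ncnc21` gives 1.9 nM in an assay on isolated protein for inhibition of adenosine deaminase (Bos taurus), with a stated time of 5 min; on this read-out lower numbers stand for stronger inhibition and higher numbers for weaker inhibition;
compound 2 `C[C@H](O)[C@@H](CCc1cccc(CO)c1)n1cnc2c(N)ncnc21` gives 4.6 nM in this assay;
compound 3 `C[C@H](O)[C@@H](CSc1ccccc1)n1cnc2c(N)ncnc21` gives 135 nM in this assay.

Compound 3 has the highest number of the three, so it is the weakest inhibitor here; its distance to the others is shown by a 71-fold higher number from compound 1 to compound 3 (1.85 log units; beyond the scatter), while a 2.4-fold higher number from compound 1 to compound 2 (0.38 log units; beyond the scatter) is modest. Compound 4 `Cc1ccccc1SC[C@H]([C@H](C)O)n1cnc2c(N)ncnc21` differs from compound 3 by methyl in place of hydrogen on an aromatic carbon. Neither measured step adds a methyl to an aromatic ring; both swap a whole side group, so they bear on this change only loosely. A small step in this assay is therefore expected for compound 4, direction uncertain. The estimated step of a 1.2-fold lower number from compound 3 to compound 4 (0.09 log units; within the scatter) gives compound 4 an expected 110 nM, ranging from 30 nM to 400 nM.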

Compound 4, inhibition constant: 66 nM
Beside the measured number, compound 4's estimate is 1.7-fold (0.22 log units) above it; the measured number falls inside the stated range.
By their numbers in this assay, from the lowest: compound 1; then compound 2; then compound 4; then compound 3.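

In this assay, putting one methyl on the ring, phenyl to 2-methylphenyl, brings a 2.0-fold lower number from compound 3 to compound 4 (0.31 log units; beyond the scatter) as a modest but real gain. The earlier steps shown here swapped whole side groups, whereas this one shows that an aromatic carbon ortho to a large group accepts an added carbon without any loss of inhibition. As far as these compounds go, whether an ethyl, a methoxy or an amine on this same carbon would act like the methyl stays open, as does the effect of a methyl on the other ring carbons. Nothing measured here explains the step.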